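One ring group swapped for another on a shared core

The source may hold more compounds than are shown below. What is called first, only, known or untested is meant among the compounds shown, and "the series" means these compounds.

- Compound 1 `CC(C)C(CC1C(=O)NC(=O)N1C)c1ccc(-c2ccc3cccc(F)c3c2)[nH]c1=O`: 33600 nM
- Compound 2 `C/C(=C1/OC(=O)NC1=O)C(c1ccc(-c2ccc3cccc(F)c3c2)[nH]c1=O)C(C)C`: 17200 nM

Both numbers come from a physicochemical assay for solubility, in phosphate buffer, measured as kinetic solubility; on this read-out lower numbers stand for lower solubility and higher numbers for higher solubility. Going by the values given here, compound 2 has only one neighbour to be read against, and the comparison shows a 2.0-fold lower number from compound 1 to compound 2 (0.29 log units; within the scatter). The two compounds therefore cannot be told apart in this measurement.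

Compound 3 `CC(C)C(/C=C1\SC(=O)NC1=O)c1ccc(-c2ccc3cccc(F)c3c2)[nH]c1=O` keeps the shared core and changes only the group on a saturated chain carbon bound to an aromatic carbon and a saturated chain carbon: a group of 8 heavy atoms (4 carbon, 1 nitrogen, 2 oxygen, 1 sulfur; one five-membered non-aromatic ring with 2 hetero atoms) in place of a group of 9 heavy atoms (5 carbon, 1 nitrogen, 3 oxygen; one five-membered non-aromatic ring with 2 hetero atoms), on a saturated chain carbon bound to an aromatic carbon and a saturated chain carbon. Among the compounds with values here, the one measured step that bears on this change sits at the same place and also exchanges one five-membered non-aromatic ring group for another. That step, a 2.0-fold lower number from compound 1 to compound 2 (0.29 log units; within the scatter), stayed within the scatter. On these data alone, it is thin evidence, and neither measured compound contains sulfur, so the new atom remains untested.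

On this basis, no change beyond the scatter is expected in this assay. The expected step is a 1.2-fold lower number from compound 2 to compound 3 (0.09 log units; within the scatter). For compound 3 the estimated value is 14000 nM, with an expected range from 4500 nM to 35000 nM.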

Compound 3, solubility: 25600 nM
The estimate for compound 3 lay 1.8-fold (0.26 log units) below the measured number; low and high end bracket the measured number.
By their numbers in this assay, from the lowest: compounds 2, 3 and 1 (each within the scatter of the next).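

In this assay, placing the sulfur-containing ring group on this saturated chain carbon gives a 1.5-fold higher number from compound 2 to compound 3 (0.17 log units; within the scatter), and the comparison with the remaining neighbour gives a 1.3-fold lower number from compound 1 to compound 3 (0.12 log units; within the scatter). The sulfur atom, which neither earlier compound carried, therefore produces no step beyond the scatter, and all three ring groups cannot be told apart in this measurement. No supporting information is available to explain why these different ring groups read alike.

All three groups are five-membered non-aromatic rings with 2 hetero atoms, so the compounds shown say nothing about how an open-chain group, such as a carboxylic acid, an amine or a longer chain, would read at this place. The shared core also stays the same throughout, which leaves open whether these ring groups would still read alike on a different core.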